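Replacing the 2-chloro-6-methoxyphenyl of compound 3 with 3,5-dimethylphenyl

A few compounds are considered here, and "the series" means these few. Any claim that something is new, unique, unknown or untested is made for them only; others in the source may bear on it.

Compound 3 `COc1cccc(Cl)c1-c1nc(CN2CCC(C(=O)NCCCN3C[C@H](C)C[C@H](C)C3)CC2)c(C)o1` is one of three compounds tested in an ADME assay on microsomes from liver (Rattus norvegicus) for metabolic stability, read by LC-MS, using NADPH, at 37 degrees C; a higher number here means that the compound lasts longer, a lower number that the compound disappears faster. Compound 1 `Cc1oc(-c2ccc(Cl)cc2)nc1CN1CCC(C(=O)NCCCN2C[C@H](C)C[C@H](C)C2)CC1` returns only a limit there, > 0.5 h. Compound 2 `Cc1oc(-c2c(Br)cccc2Br)nc1CN1CCC(C(=O)NCCCN2C[C@H](C)C[C@H](C)C2)CC1` gives 0.035 h in this assay, and compound 3 gives 0.055 h. Among the two actual numbers compound 3 holds the higher one, but the step between them is a 1.6-fold higher number from compound 2 to compound 3 (0.20 log units; within the scatter), so the two cannot be ranked. The two steps that leave the 4-chlorophenyl of compound 1 are both clearly downward: an at least 14-fold lower number from compound 1 to compound 2 (1.15 log units; beyond the scatter) and an at least 9.0-fold lower number from compound 1 to compound 3 (0.95 log units; beyond the scatter), with the starting point a limit (the limit of > 0.5 h in this assay, at which 1 of the 3 values shown sits).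

The step now followed leads to compound 4 `Cc1cc(C)cc(-c2nc(CN3CCC(C(=O)NCCCN4C[C@H](C)C[C@H](C)C4)CC3)c(C)o2)c1`, with the change (3,5-dimethylphenyl in place of 2-chloro-6-methoxyphenyl on an aromatic carbon). No measured step moves between a 3,5-dimethylphenyl and any other group, so the bearing of the earlier steps is indirect: both large losses came with a change away from 4-chlorophenyl, and the return toward a simpler aryl group in compound 4 is taken as a reason to expect a higher number than compound 3 shows with 0.055 h. Compound 4 is therefore expected to move by a 3.6-fold higher number from compound 3 to compound 4 (0.56 log units; beyond the scatter) in this assay, landing at an estimated 0.2 h with a range of 0.05 h to 0.8 h.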

Compound 4, half-life: < 0.5 h
Compound 4 ended at the assay's limit (the forecaster's own chance of this, stated with the estimate: 25%); the middle value is on the limit's open side.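

In this assay the entry for compound 4 is a limit and not a number: the limit of < 0.5 h in this assay, at which 1 of the 4 values shown sits. The 4-chlorophenyl entry for compound 1 is also a limit: the limit of > 0.5 h in this assay, at which 1 of the 4 values shown sits. Read against each other, these two limits give a number no higher from compound 1 to compound 4 (the limit leaves the size open), so at this aromatic carbon 3,5-dimethylphenyl does not match the side of the limit held by 4-chlorophenyl, although the size of that step stays open. Going by these compounds, the steps from compound 2 and compound 3 to compound 4 cannot be read, so the position of 3,5-dimethylphenyl relative to 2,6-dibromophenyl and 2-chloro-6-methoxyphenyl remains unknown.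

The compounds shown leave open how far compound 4 lies from the limit and whether a single methyl group in place of the two, as in 4-methylphenyl, would give a readable number. They also leave open how a pyridine ring at this same aromatic carbon would compare with the carbon-only aromatic rings shown.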